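Swapping the Sulfonyl Aryl Group in a Weakly Active Series

The compounds below may be only part of what the source reports. "The series", "measured", "known", "first", "only" and "open" are said of these compounds alone.

Compound 1 `CC(=O)Nc1ccc(S(=O)(=O)NNC(=O)c2cccnc2Nc2ccc(Cl)cc2)cc1` was tested in a functional assay on A549 cells (Homo sapiens) for antiproliferative activity; a lower number here means that less compound is tolerated, a higher number that more compound is tolerated. In this assay compound 1 reaches only the limit of the measurement, > 100000 nM, so no number is known for it (the limit of > 100000 nM in this assay, at which 1 of the 2 values shown sits). A related compound, compound 2 `O=C(NNS(=O)(=O)c1ccc(F)cc1)c1cccnc1Nc1ccc(Cl)cc1Cl`, gives in this assay a value of 97700 nM; the two results show that neither compound is strongly active against these cells. Compound 3 `O=C(NNS(=O)(=O)c1ccc(Cl)cc1Cl)c1cccnc1Nc1ccc(Cl)cc1` has not yet been measured. It differs from compound 1 by the change (2,4-dichlorophenyl in place of 4-acetamidophenyl on a sulfonyl sulfur), that is 2,4-dichlorophenyl in place of 4-acetamidophenyl on a sulfonyl sulfur. Among the compounds with values here, no measured pair shows what this change does, and with both known compounds weak, the step in this assay is expected to be small, of no clear direction, and likely not beyond the scatter. Compound 3 is therefore expected to give about 80000 nM, within 30000 nM to 100000 nM. The step from compound 1 to compound 3 is thus estimated at an at least 1.2-fold lower number from compound 1 to compound 3 (0.09 log units; that floor lies within the scatter).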

Compound 3, concentration lethal to 50% of the cells: > 100000 nM
Compound 3: only a limit was reported (the forecaster's own chance of this, stated with the estimate: 45%); middle value at least 1.2-fold (0.09 log units) from the limit.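

Compound 1 and compound 3 both reach only the limit of the measurement, so no step between them can be read: the limit of > 100000 nM in this assay, at which 2 of the 3 values shown sit.

The compounds shown leave open whether 2,4-dichlorophenyl in place of 4-acetamidophenyl on a sulfonyl sulfur changes the value in this assay at all.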